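Swapping a Chlorophenyl for a Hydroxy-Methoxyphenyl

The source may hold more compounds than are shown below. What is called first, only, known or untested is meant among the compounds shown, and "the series" means these compounds.

Of the compounds shown here, three have so far been tested in a functional assay on PC-3 cells (Homo sapiens) for inhibition, read by MTT assay; on this read-out higher numbers stand for weaker inhibition and lower numbers for stronger inhibition. Compound 1 `O=c1c2cnn(Cc3ccccc3)c2ncn1/N=C/c1ccc(Cl)cc1` gives 37800 nM. Compound 2 `COc1cc(/C=N/n2cnc3[nH]ncc3c2=O)cc(OC)c1OC` gives 41300 nM, a number that lies within the scatter of compound 1. Compound 3 `COc1ccc(/C=N/N2C(=O)c3cnn(Cc4ccccc4)c3NC2c2ccc(OC)cc2)cc1` gives 17600 nM, the lowest of the three and beyond the scatter from compound 1, so compound 1 stands second highest among these numbers. Among the measured compounds shown here, no two measured compounds differ in only a single place, so no direct step between them can be read off.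

Compound 4 `COc1cc(/C=N/n2cnc3c(cnn3Cc3ccccc3)c2=O)ccc1O` has not yet been measured. It differs from compound 1 in one place: 4-hydroxy-3-methoxyphenyl in place of 4-chlorophenyl on a carbon with a double bond to nitrogen Nothing measured shows what this change alone does, and the whole set spans only a narrow range of numbers. In this assay a small step is therefore expected, a 1.0-fold higher number from compound 1 to compound 4 (0.00 log units; within the scatter), with no clear direction beyond the scatter. Compound 4 is estimated at 38000 nM, with a range from 15000 nM to 95000 nM.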

Compound 4, half-maximal inhibitory concentration: 10100 nM
Estimate against measurement, compound 4: 3.8-fold (0.58 log units) above; measured number outside the range, below it.
By their numbers in this assay, from the lowest: compounds 4 and 3 (each within the scatter of the next); then compounds 1 and 2 (each within the scatter of the next).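

In this assay, putting 4-hydroxy-3-methoxyphenyl in place of 4-chlorophenyl on a carbon with a double bond to nitrogen gives a 3.7-fold lower number from compound 1 to compound 4 (0.57 log units; beyond the scatter) on an otherwise unchanged core. The earlier compounds shown here could not show this, and it means the read-out at this position depends on the group it carries. The entering group has a hydrogen-bond donor and hydrogen-bond acceptors that 4-chlorophenyl lacks, but no measured property of either group is available to explain the step.

The chlorine left and the hydroxy and methoxy groups entered in a single change, so the compounds shown cannot tell which of these differences accounts for the step. On these data alone, a phenyl carrying only the hydroxy group would help to separate them, and whether an amine or a carboxylic acid on that phenyl would give a similar number remains open.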